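The source may report more compounds than this note shows. Statements on the series, on what has been measured and on what is new or still open speak of the compounds shown alone.

Compound 1 `O=C(CSc1nnnn1-c1ccccc1)N/N=c1/scc(-c2ccccc2)n1-c1ccccc1` and compound 2 `O=C(CSc1nnnn1-c1ccccc1)N/N=c1/scc(-c2ccc(F)cc2)n1-c1ccccc1` share one core and differ only in a single group. In a functional assay on C6 cells (Rattus norvegicus) for cytotoxicity, read by MTT assay, with a stated time of 24 h (a higher number here means a weaker inhibitor, a lower number a stronger inhibitor), compound 1 gives 8.3 ug/mL, and compound 2 gives 24.3 ug/mL, a step of a 2.9-fold higher number from compound 1 to compound 2 (0.47 log units; beyond the scatter). Compound 3 `O=C(CSc1nnnn1-c1ccccc1)N/N=c1/scc(-c2ccc([N+](=O)[O-])cc2)n1-c1ccccc1` carries a nitro group on the same ring, but in this assay compound 3 gives "not determined" (no result reported), so it cannot be placed on these numbers. Compound 4 `N#Cc1ccc(-c2cs/c(=N/NC(=O)CSc3nnnn3-c3ccccc3)n2-c2ccccc2)cc1` differs from compound 3 by cyano in place of nitro on an aromatic carbon. Within the data shown here, no measured step covers cyano in place of nitro on an aromatic carbon; the single measured step concerns a different change and gives no direction for this one. For compound 4 the value in this assay is therefore estimated near the measured compounds, at 15 ug/mL, within 5 ug/mL to 45 ug/mL.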

Compound 4, half-maximal inhibitory concentration: > 200 ug/mL
Compound 4: no number, only a limit; the forecaster's own chance of this, stated with the estimate: 10%; at least 13-fold (1.12 log units) between middle value and limit.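

Compound 4 gives only a limit in this assay, not a number: the limit of > 200 ug/mL in this assay, at which 1 of the 4 values shown sits.

At this place, para to a large group, cyano in place of fluoro gives an at least 8.2-fold higher number from compound 2 to compound 4 (0.91 log units; beyond the scatter), and cyano in place of hydrogen gives an at least 24-fold higher number from compound 1 to compound 4 (1.38 log units; beyond the scatter). Among the compounds with a result, each of the two groups raises the number over hydrogen, and cyano raises it further than fluoro does.

Compound 3 has no result, so nitro cannot be set against cyano. From the compounds shown here alone, how an amine or a methyl group at this place would read remains open.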